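Lengthening the alkenyl amide chain at the assay limit

The compounds below may be only part of what the source reports. "The series", "measured", "known", "first", "only" and "open" are said of these compounds alone.

Measured in a functional assay on MCF7 cells (Homo sapiens) for antiproliferative activity, read by MTT assay, with a stated time of 72 h; a higher number here means a weaker inhibitor, a lower number a stronger inhibitor:
- compound 1 `C=CC(=O)Nc1cccc(Oc2nc(Nc3ccn(C)n3)nc3c2CSCC3)c1`: > 50000 nM (a limit)
- compound 2 `CC/C=C/C(=O)Nc1cccc(Oc2nc(Nc3ccn(C)n3)nc3c2CSCC3)c1`: > 50000 nM (a limit)

Compound 2 stands at > 50000 nM, which is a limit and not a number. The whole record so far is the limit of > 50000 nM in this assay, at which 2 of the 2 values shown sit.

Compound 3 `CCC/C=C/C(=O)Nc1cccc(Oc2nc(Nc3ccn(C)n3)nc3c2CSCC3)c1` carries pent-1-en-1-yl where compound 2 carries but-1-en-1-yl. The counted change is methyl in place of hydrogen on a saturated chain carbon, two bonds along the chain from a double-bonded chain carbon.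

Among the measured compounds shown here, only one measured step bears on this: a step that the two limits leave unreadable from compound 1 to compound 2. It offers no size to carry forward, so no step beyond the scatter is expected in this assay, in either direction. Another limit is the most likely report. The expected change is a number no higher from compound 2 to compound 3 (the limit leaves the size open). Should a number appear, compound 3 is estimated at 50000 nM, with an expected range of 25000 nM to 100000 nM.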

Compound 3, half-maximal inhibitory concentration: 22600 nM
For compound 3 the middle estimate is 2.2-fold (0.34 log units) above the measured one, and the stated range ends above it.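

In this assay, among the compounds shown here, compound 3 is the only one of the three compounds with a number rather than a limit, so the length of this alkenyl chain now has a visible bearing on the read-out. Methyl in place of hydrogen on a saturated chain carbon, two bonds along the chain from a double-bonded chain carbon, gives an at least 2.2-fold lower number from compound 2 to compound 3 (0.34 log units; beyond the scatter), and the change of the whole alkenyl chain gives an at least 2.2-fold lower number from compound 1 to compound 3 (0.34 log units; beyond the scatter). Both steps start from a limit, so their full size stays open, and the step between the two shorter chains cannot be read: the limit of > 50000 nM in this assay, at which 2 of the 3 values shown sit.

One number does not establish a trend with chain length. The compounds shown leave open how a longer alkenyl chain, a saturated pentyl chain or an amine on the chain would read.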